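A small methyl added to the pyridine arm

The source may hold more compounds than are shown below. What is called first, only, known or untested is meant among the compounds shown, and "the series" means these compounds.

Compound 1 `Cc1nc(CN2CCC[C@H]2c2ccccn2)cc(N2CCN(C)CC2)n1` is the reference point here. For the measured compounds named here, in an assay on HPBALL cells for binding affinity to C-X-C chemokine receptor type 4 (Homo sapiens), read by flow cytometry, with a stated time of 3 h (on this read-out lower numbers stand for stronger inhibition and higher numbers for weaker inhibition), compound 1 gives 220 nM, the only actual number in this set. Its mirror-image partner, compound 2 `Cc1nc(CN2CCC[C@@H]2c2ccccn2)cc(N2CCN(C)CC2)n1`, reaches only a limit in this assay: compound 2 shows > 10000 nM, which is the edge of what the assay reports rather than a measured number. The step of an at least 45-fold higher number from compound 1 to compound 2 (1.65 log units; beyond the scatter) therefore shows that flipping the single stereocentre at the saturated ring carbon costs a great deal of binding.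

Compound 3 `Cc1ccc([C@@H]2CCCN2Cc2cc(N3CCN(C)CC3)nc(C)n2)nc1` keeps the configuration of compound 1 and changes something else: methyl in place of hydrogen on an aromatic carbon, that is, pyridin-2-yl becomes 5-methylpyridin-2-yl. Going by the values given here, the one measured step, between compound 1 and compound 2, concerns configuration alone and does not speak to a methyl on the aromatic ring. Among the compounds with values here, with no measured step bearing on this change, the expectation for compound 3 in this assay is a step of no change at the digits printed from compound 1 to compound 3 (within the scatter) that stays within the scatter. The estimated value for compound 3 is 220 nM, with a range from 70 nM to 700 nM.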

Compound 3, half-maximal inhibitory concentration: 278 nM
Compound 3: middle estimate off by 1.3-fold (0.10 log units), on the low side; low and high end bracket the measured number.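

In this assay, replacing pyridin-2-yl with 5-methylpyridin-2-yl gives a 1.3-fold higher number from compound 1 to compound 3 (0.10 log units; within the scatter), so this aromatic carbon, two atoms from the ring nitrogen and para to a large group, accepts a methyl with no difference that can be told from the usual scatter. For the compounds shown here, compounds 1 and 2 spoke only about configuration at the saturated ring carbon, whereas this step is the first reading on the aromatic ring itself, and it shows that binding in the configuration of compound 1 survives this small addition. Nothing shown here accounts for why the methyl makes so little difference.

A single methyl marks out only a small part of what this position might accept, and a longer chain such as propyl, a methoxy group, an amine or a carboxylic acid at the same carbon could give a very different result. The compounds shown also leave open how a methyl would fare on the other carbons of the pyridine ring, and whether it would read the same way in the configuration of compound 2.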